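The source may report more compounds than this note shows. Statements on the series, on what has been measured and on what is new or still open speak of the compounds shown alone.

Of the compounds shown here, two have been measured in a physicochemical assay for solubility, read by HPLC, using the shake flask method, measured as kinetic solubility, with a stated time of 2 h, at pH 7.4; a higher number here means a more soluble compound, a lower number a less soluble compound. Compound 1, with structure `Cc1cc(NCc2cnccn2)n2nc(C)c(-c3ccccc3)c2n1`, gives 7100 nM. Compound 2, with structure `Cc1cc(NCc2ccccn2)n2ncc(-c3ccc(N(C)C)cc3)c2n1`, returns only a limit in this assay, < 5000 nM, so its true solubility is known only to lie on one side of that boundary. This is the limit of < 5000 nM in this assay, at which 1 of the 2 values shown sits, which means that of the two numbers shown, one is a real reading and one is a boundary.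

The step to be judged leads from compound 2 to compound 3, whose structure is `Cc1cc(NCc2ccccn2)n2ncc(-c3cc(F)c(F)c(F)c3)c2n1`. The change is 3,4,5-trifluorophenyl in place of 4-(dimethylamino)phenyl on an aromatic carbon, on an aromatic carbon of a five-membered aromatic ring with 2 nitrogen, part of a fused or bridged system of two rings.

Among the measured compounds shown here, no measured pair differing in one place is available, so the size of the step can only be guessed. Because compound 2 already sits at the limit described by the limit of < 5000 nM in this assay, at which 1 of the 2 values shown sits, compound 3 is expected to remain near or under that same boundary, and the step that the limit leaves unreadable from compound 2 to compound 3 is expected to be small, within the scatter or modestly downward. Compound 3 is therefore estimated at 2500 nM, with a plausible range from 600 nM to 8000 nM.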

Compound 3, solubility: < 5000 nM
Compound 3: no number, only a limit; the forecaster's own chance of this, stated with the estimate: 65%; the middle value does not contradict the limit.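

Compound 2 and compound 3 both return only a limit in this assay, so no step between them can be read: the limit of < 5000 nM in this assay, at which 2 of the 3 values shown sit.

On these data alone, what stays open is how the true solubilities of compound 2 and compound 3 compare, and so whether 3,4,5-trifluorophenyl in place of 4-(dimethylamino)phenyl changes solubility at all.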